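A few compounds are considered here, and "the series" means these few. Any claim that something is new, unique, unknown or untested is made for them only; others in the source may bear on it.

Three related compounds have been measured so far in a functional assay on MCF7 cells (Homo sapiens) for antiproliferative activity, read by MTT assay, with a stated time of 24 h; a higher number here means a weaker inhibitor, a lower number a stronger inhibitor. Compound 1 `Cc1ccc(-c2nn(-c3ccccc3)cc2-c2nc3ccccc3n2S(=O)(=O)c2cc(C)ccc2C)cc1` gives 510 nM and compound 2 `O=S(=O)(c1ccccc1)n1c(-c2cn(-c3ccccc3)nc2-c2ccc(F)cc2)nc2ccccc21` gives 690 nM while compound 3 `O=S(=O)(c1ccccc1)n1c(-c2cn(-c3ccccc3)nc2-c2ccc(C(F)(F)F)cc2)nc2ccccc21` gives 630 nM and so stands level with both, since no gap among the three exceeds the usual scatter of repeat measurements. Compound 4 `Cc1ccc(C)c(S(=O)(=O)n2c(-c3cn(-c4ccccc4)nc3-c3ccc(C(F)(F)F)cc3)nc3ccccc32)c1` differs from compound 3 in one place, with 2,5-dimethylphenyl in place of phenyl on a sulfonyl sulfur. Among the compounds with values here, the only measured one-place step is a different change, trifluoromethyl in place of fluoro (a 1.1-fold lower number from compound 2 to compound 3 (0.04 log units; within the scatter)), so no measured step covers this swap directly. The nearest hint is compound 1, which also carries 2,5-dimethylphenyl on its sulfonyl sulfur and gives 510 nM in this assay despite differing from compound 3 elsewhere too. No step beyond the scatter is therefore expected. The estimated step is a 1.1-fold lower number from compound 3 to compound 4 (0.05 log units; within the scatter) and its direction is uncertain. Compound 4 is estimated at 560 nM and expected to fall from 280 nM to 1100 nM in repeat measurements.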

Compound 4, half-maximal inhibitory concentration: 170 nM
Estimate against measurement, compound 4: 3.3-fold (0.52 log units) above; measured number outside the range, below it.
By their numbers in this assay, from the lowest: compound 4; then compounds 1, 3 and 2 (each within the scatter of the next).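

In this assay, within the data shown here, the ring on the sulfonyl sulfur turns out to matter: 2,5-dimethylphenyl in place of phenyl gives a 3.7-fold lower number from compound 3 to compound 4 (0.57 log units; beyond the scatter), the first single change here to go beyond the scatter. The other end of the molecule matters too, at least with 2,5-dimethylphenyl on the sulfonyl sulfur, since changing methyl to trifluoromethyl at an aromatic carbon gives a 3.0-fold lower number from compound 1 to compound 4 (0.48 log units; beyond the scatter), so the step from the earlier pair, a 1.1-fold lower number from compound 2 to compound 3 (0.04 log units; within the scatter), does not describe every change at that aromatic carbon. Nothing available explains the origin of either gain.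

On these data alone, whether both methyl groups of the 2,5-dimethylphenyl are needed remains open. So does what a methoxy group or an amine would do in their place.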